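The compounds below may be only part of what the source reports. "The series", "measured", "known", "first", "only" and "open" are said of these compounds alone.

Among the measured compounds shown here, compound 2 `O=c1[nH]c(=O)n([C@@H]2O[C@H](CO)[C@@H](O)[C@H]2O)cc1C#Cc1ccccc1` gives 78400 nM in an ADME assay on Vero cells (Chlorocebus sabaeus) for cytotoxicity, read by MTT assay (on this read-out higher numbers stand for lower toxicity in this test and lower numbers for higher toxicity in this test), the lower of the two numbers measured so far, with compound 1 `O=c1[nH]c(=O)n([C@@H]2O[C@H](CO)[C@@H](O)[C@H]2O)cc1C#CC1CCCCC1` at 148000 nM lying within the scatter of it. Compound 3 `O=c1[nH]c(=O)n([C@@H]2O[C@H](CO)[C@@H](O)[C@H]2O)cc1C#CC1CC1` differs from compound 2 by cyclopropyl in place of phenyl on a triple-bonded carbon. For the measured compounds named here, the only measured step that bears on this change, a 1.9-fold lower number from compound 1 to compound 2 (0.28 log units; within the scatter), also swapped the ring on the triple-bonded carbon and stayed within the scatter. No movement beyond the scatter is therefore expected, a 1.3-fold higher number from compound 2 to compound 3 (0.11 log units; within the scatter). Compound 3 is estimated at 100000 nM, within a range from 40000 nM to 250000 nM.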

Compound 3, half-maximal cytotoxic concentration: 133000 nM
Estimate against measurement, compound 3: 1.3-fold (0.12 log units) below; the measured number falls inside the stated range.
By their numbers in this assay, from the lowest: compounds 2, 3 and 1 (each within the scatter of the next).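

Cyclopropyl on the triple-bonded carbon gives no movement beyond the scatter in this assay: there is a 1.7-fold higher number from compound 2 to compound 3 (0.23 log units; within the scatter) and a 1.1-fold lower number from compound 1 to compound 3 (0.05 log units; within the scatter). Going from the 6 heavy atoms of phenyl to the 3 of cyclopropyl, with an aromatic ring replaced by a non-aromatic one, thus leaves the number within the scatter, and all three rings sit within the scatter of one another. No measurement at hand accounts for this. Still open, as far as these compounds go, is whether a group that is not a carbon ring, such as an amine or a carboxylic acid, or a longer chain at this place would move the number beyond the scatter.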